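A few compounds are considered here, and "the series" means these few. Any claim that something is new, unique, unknown or untested is made for them only; others in the source may bear on it.

Compound 1 `COc1cc(N)c(Cl)cc1NC(=O)C1CCN(Cc2cccc(C)c2)CC1` gives 2.4 mg/kg in a functional assay on the whole organism for antagonist activity, with Mus musculus as the target; on this read-out higher numbers stand for an effect only at larger amounts of compound and lower numbers for an effect already at smaller amounts. Compound 2 `COc1cc(N)c(Cl)cc1NC(=O)C1CCN(Cc2ccc([N+](=O)[O-])cc2)CC1` sits at the limit of > 4 mg/kg in this assay, at which 1 of the 2 values shown sits. In this assay compound 2 gives > 4 mg/kg, a limit of the assay and not a number. For the measured compounds named here, the only measured step is an at least 1.6-fold higher number from compound 1 to compound 2 (0.22 log units; that floor lies within the scatter), whose floor lies within the scatter. Going by the values given here, compound 3 `CCCCCN1CCC(C(=O)Nc2cc(Cl)c(N)cc2OC)CC1` differs from compound 2 by butyl in place of 4-nitrophenyl on a saturated chain carbon bound to an amine nitrogen in a ring; no measured step covers an exchange of an aromatic ring for a chain, so no direction is fixed. The step of a number no higher from compound 2 to compound 3 (the limit leaves the size open) is expected to be small. Compound 3 is estimated at 4 mg/kg, between 1.5 mg/kg and 12 mg/kg.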

Compound 3, dose for half-maximal effect: > 10 mg/kg
Compound 3: a limit, no number; the forecaster's own chance of this, stated with the estimate: 45%; middle value at least 2.5-fold (0.39 log units) away from the limit.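

Butyl in place of 3-methylphenyl on a saturated chain carbon bound to an amine nitrogen in a ring gives, in this assay, an at least 4.1-fold higher number from compound 1 to compound 3 (0.61 log units; beyond the scatter), the first step in the series beyond the scatter. The value of compound 3 is a limit and not a number: the limit of > 10 mg/kg in this assay, at which 1 of the 3 values shown sits. The values of compound 2 and compound 3 are both limits, and the step between them cannot be read.

Open, going by these compounds, is whether cyclohexyl or a longer chain at this place would stay close to compound 1. Also open, on these data alone, is how large the true values of compound 2 and compound 3 are.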